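Swapping Methoxy for Cyano on an Inactive Series

This account rests on a few compounds, and the source may have more. Where it says the series, first, only, none or still open, it means among the compounds named here.

Three compounds sharing one core were tested in a functional assay on SK-OV-3 cells (Homo sapiens) for inhibition, read by MTT assay, with a stated time of 24 h; on this read-out higher numbers stand for weaker inhibition and lower numbers for stronger inhibition. Compound 1, `CCOC(=O)c1c(C)[nH]c(=O)c(C#N)c1-c1ccccc1`, carries an unsubstituted phenyl ring. In this assay compound 1 reaches only the limit > 100000 nM. Compound 2, `CCOC(=O)c1c(C)[nH]c(=O)c(C#N)c1-c1ccc(OC)cc1`, bears a methoxy group on that ring. For compound 2 the assay again reports only a limit, > 100000 nM. Compound 3, `CCOC(=O)c1c(C)[nH]c(=O)c(C#N)c1-c1ccc([N+](=O)[O-])cc1`, bears a nitro group instead. Compound 3 likewise stops at the limit > 100000 nM. Because the limit of > 100000 nM in this assay, at which 3 of the 3 values shown sit, holds for every value, none of the steps between these compounds can be read: a step that the two limits leave unreadable from compound 1 to compound 2, a step that the two limits leave unreadable from compound 1 to compound 3 and a step that the two limits leave unreadable from compound 2 to compound 3 all have no readable size.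

Compound 4, `CCOC(=O)c1c(C)[nH]c(=O)c(C#N)c1-c1ccc(C#N)cc1`, is the next member. Its change from compound 2 is cyano in place of methoxy on an aromatic carbon. The measured steps that bear on this change are the ones that also exchange a group on an aromatic carbon, a step that the two limits leave unreadable from compound 2 to compound 3 and a step that the two limits leave unreadable from compound 1 to compound 2, and neither gave a readable size. So in this assay no step beyond the scatter is expected in either direction, and a fourth limit is the most probable outcome. Compound 4 is therefore expected to sit near 150000 nM, within a range from 50000 nM to 500000 nM. The estimated step that the limit leaves unreadable from compound 2 to compound 4 is thus expected to be essentially flat.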

Compound 4, half-maximal inhibitory concentration: > 100000 nM
Compound 4 ended at the assay's limit; the forecaster's own chance of this, stated with the estimate: 85%; the middle value lies beyond the limit too.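

No step among compound 1, compound 2, compound 3 and compound 4 can be read, because all four results in this assay are limits rather than numbers: the limit of > 100000 nM in this assay, at which 4 of the 4 values shown sit.

The compounds shown leave open how strongly any of them inhibits in this assay, and whether hydrogen, methoxy, nitro or cyano on the ring makes any difference.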